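The compounds below may be only part of what the source reports. "The series", "measured", "known", "first", "only" and "open" are said of these compounds alone.

Measured so far:
- compound 1 `CCCCc1cc2c(=O)c(-c3ccccc3)c(C)[nH]c2cc1OCCOc1ccccc1` gives 23000 nM
- compound 2 `CCCCc1cc2c(=O)c(-c3ccc(C(F)(F)F)cc3)c(C)[nH]c2cc1OCCOc1ccccc1` gives 20000 nM
- compound 3 `CCCCc1cc2c(=O)c(-c3ccc(OC(F)(F)F)cc3)c(C)[nH]c2cc1OCCOc1ccccc1` gives 20000 nM

In an ADME assay on J774 cells (Mus musculus) for antiproliferative activity, with a stated time of 72 h (a higher number here means that more compound is needed for the effect, a lower number that less compound is needed), compound 1 gives 23000 nM and stands level with the other two compounds within the scatter.

Compound 4 `CCCCc1cc2c(=O)c(-c3cccc(Oc4ccc(F)cc4)c3)c(C)[nH]c2cc1OCCOc1ccccc1` is compound 1 with one change: 4-fluorophenoxy in place of hydrogen on an aromatic carbon. The 4-fluorophenoxy replaces hydrogen on an aromatic carbon, meta to a large group.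

Two measured steps also replace hydrogen on an aromatic carbon. Trifluoromethyl gave a 1.2-fold lower number from compound 1 to compound 2 (0.06 log units; within the scatter) and trifluoromethoxy gave a 1.2-fold lower number from compound 1 to compound 3 (0.06 log units; within the scatter). Exchanging these two groups gave no change at the digits printed from compound 2 to compound 3 (within the scatter). Neither group is a 4-fluorophenoxy, so these steps are only indirect evidence and the range stays wide.

No step beyond the scatter is expected in this assay, and no direction can be assigned with confidence. The expected change is a 1.3-fold lower number from compound 1 to compound 4 (0.11 log units; within the scatter).

The estimate for compound 4 is 18000 nM, with an expected range of 7000 nM to 35000 nM.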

Compound 4, half-maximal effective concentration: 19000 nM
The estimate for compound 4 lay 1.1-fold (0.02 log units) below the measured number; the range from low to high includes it.
By their numbers in this assay, from the lowest: compounds 4, 2, 3 and 1 (each within the scatter of the next).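

In this assay the 4-fluorophenoxy on this aromatic carbon, meta to a large group, gives a 1.2-fold lower number from compound 1 to compound 4 (0.08 log units; within the scatter) and so leaves compound 4 level with compound 1. This adds something that compound 2 and compound 3 did not show: a substituent carrying a whole further six-membered aromatic ring of carbon only can stand here with no step beyond the scatter. No measurement is at hand that explains this result.

On these data alone, whether any substituent at this position can move the number beyond the scatter stays open, and an amine, a carboxylic acid or a longer chain in place of the hydrogen would test that. Also open, as far as these compounds go, is whether the fluorine matters, which plain phenoxy would show, and whether the butyl chain or the phenoxyethoxy chain on the shared core has more effect on the number.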